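Varying the group on the aromatic nitrogen

This account rests on a few compounds, and the source may have more. Where it says the series, first, only, none or still open, it means among the compounds named here.

Three analogues of a shared core have been measured in an assay on Prostate gland for inhibition of steroid 5-alpha-reductase (Rattus norvegicus); on this read-out higher numbers stand for weaker inhibition and lower numbers for stronger inhibition. Compound 1 `CCCn1ccc2cc(/C(C)=C/C(=O)Nc3ccccc3OCCCC(=O)O)ccc21` gives 190 nM. Compound 2 `CCCCCCCn1ccc2cc(/C(C)=C/C(=O)Nc3ccccc3OCCCC(=O)O)ccc21` gives 120 nM. Compound 3 `C/C(=C\C(=O)Nc1ccccc1OCCCC(=O)O)c1ccc2c(ccn2CC(C)C)c1` gives 160 nM. Among these three numbers compound 3 stands second highest; it lies within the scatter of both neighbours, as shown by the steps of a 1.2-fold lower number from compound 1 to compound 3 (0.07 log units; within the scatter) and a 1.3-fold higher number from compound 2 to compound 3 (0.12 log units; within the scatter).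

Compound 4 `CCCC(C)n1ccc2cc(/C(C)=C/C(=O)Nc3ccccc3OCCCC(=O)O)ccc21` has not yet been measured in this assay. It differs from compound 3 in one place: 1-methylbutyl in place of isobutyl on an aromatic nitrogen. The measured steps that bear on this change are those that also alter only the group on the aromatic nitrogen. The step of a 1.6-fold lower number from compound 1 to compound 2 (0.20 log units; within the scatter) lengthened the chain there; the step of a 1.2-fold lower number from compound 1 to compound 3 (0.07 log units; within the scatter) placed a methyl on it; the step of a 1.3-fold higher number from compound 2 to compound 3 (0.12 log units; within the scatter) exchanged hexyl for isopropyl. None of the three moved the number beyond the scatter, and together they give no sign that the size or shape of this group matters within the range covered.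

For compound 4 no step beyond the scatter is therefore expected in this assay. The expected step is a 1.1-fold lower number from compound 3 to compound 4 (0.06 log units; within the scatter). Compound 4 is estimated at 140 nM, with a range from 70 nM to 280 nM.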

Compound 4, half-maximal inhibitory concentration: 7.8 nM
Compound 4: the middle estimate sits 18-fold (1.25 log units) above what was measured; measured number below the stated range.
By their numbers in this assay, from the lowest: compound 4; then compounds 2, 3 and 1 (each within the scatter of the next).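

The group on the aromatic nitrogen does matter in this assay: a 21-fold lower number from compound 3 to compound 4 (1.31 log units; beyond the scatter), a 15-fold lower number from compound 2 to compound 4 (1.19 log units; beyond the scatter) and a 24-fold lower number from compound 1 to compound 4 (1.39 log units; beyond the scatter) are all beyond the scatter, whereas propyl, heptyl and isobutyl all lie within the scatter of one another. Chain size alone does not sort these four compounds, since the propyl of compound 1 and the heptyl of compound 2 both give numbers well above that of compound 4, and among the groups shown only 1-methylbutyl carries a methyl branch on the saturated chain carbon bound to the aromatic nitrogen, though this rests on compound 4 alone. Nothing available bears on why this one change has so large an effect.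

Still open, from the compounds shown here alone, is whether isopropyl, 1-ethylpropyl or a ring such as cyclopentyl on the aromatic nitrogen would give a number close to that of compound 4, which would show whether the branch itself or the exact 1-methylbutyl group is what counts. Also open, going by these compounds, are how the two mirror-image forms of 1-methylbutyl compare and whether a hydroxyl or an amine on this group would keep the low number.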